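The source may report more compounds than this note shows. Statements on the series, on what has been measured and on what is new or still open speak of the compounds shown alone.

Compound 1 `O=C1NC(=S)/C(=C/c2cccc(Cl)c2)S1` gives 18.8%
Compound 2 `O=C1NC(=S)/C(=C/c2ccc(Cl)c(Cl)c2)S1` gives 16.4%

Both values come from a functional assay on HEp-2 cells (Homo sapiens) for cytotoxicity, read by MTT assay, with a stated time of 72 h, tested at 10 ug/mL (a lower number here means less inhibition of growth, a higher number more inhibition of growth at the concentration tested), and are all that has been measured so far. Within the data shown here, the one step between them, a number 2.4 percentage points lower from compound 1 to compound 2 (within the scatter), lies within the scatter, so compound 1 stands level with the only other measured compound and the two cannot be ranked.

Compound 3 `O=C1NC(=S)/C(=C/c2cccc(Br)c2)S1` has not yet been measured. It keeps the core of compound 1 and differs in one group: bromo in place of chloro on an aromatic carbon, which is bromo in place of chloro on an aromatic carbon.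

Among the measured compounds shown here, no measured step shows this exact swap. The closest evidence is chloro in place of hydrogen on an aromatic carbon, a different change, whose size of a number 2.4 percentage points lower from compound 1 to compound 2 (within the scatter) stays within the scatter. With so little to go on, the starting point is compound 1 at 18.8% and no step beyond the scatter is expected in this assay, in either direction.

The expected step is small, a number 0.8 percentage points lower from compound 1 to compound 3 (within the scatter), and the estimate carries no real direction. The estimated value for compound 3 is 18%, with an expected range from 8% to 30%.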

Compound 3, percent growth inhibition at one concentration: 23.6%
Estimate against measurement, compound 3: 5.6 percentage points below, and the stated range covers the measured number.
By their numbers in this assay, from the lowest: compounds 2, 1 and 3 (each within the scatter of the next).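

In this assay, the exchange of chloro for bromo on an aromatic carbon, meta to a group of 8 heavy atoms, gives a number 4.8 percentage points higher from compound 1 to compound 3 (within the scatter). The earlier pair showed only what happens when a second chloro joins the ring, whereas this step replaces the halogen already at this place, and the read-out stays within the usual scatter, so this one exchange gives no measurable sign that the choice between these two halogens matters here. Nothing measured alongside these compounds accounts for the size of this step, and a step inside the scatter would give little to account for in any case.

On these data alone, these compounds carry only chloro and bromo on the ring, so it remains open whether a group of a different kind at this place, such as an amine, a methoxy or a carboxylic acid, would move the number beyond the scatter. As far as these compounds go, it is also open whether the exchange of chloro for bromo would give a similar result in compound 2, which carries a second chloro.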